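Changing one aromatic group: what happens to clearance?

A few compounds are considered here, and "the series" means these few. Any claim that something is new, unique, unknown or untested is made for them only; others in the source may bear on it.

Three measured compounds share a core and differ in one group on it. In an ADME assay (liver) for metabolic stability, with Liver microsome (Homo sapiens) as the target, using microsomes and NADPH, with a stated time of 30 min, tested at 1 uM (a lower number here means slower removal, a higher number faster removal of the compound), compound 1 `COc1cc(C(O)(C(F)(F)F)C(F)(F)F)cnc1N1CCN(S(=O)(=O)c2ccc(N)nc2)CC1` gives < 14 mL.min-1.g-1, which is a limit of the assay and not a number. Compound 2 `Nc1ccc(S(=O)(=O)N2CCN(c3ncc(C(O)(C(F)(F)F)C(F)(F)F)cc3C3CC3)CC2)cn1` gives 38 mL.min-1.g-1. Compound 3 `CS(=O)(=O)c1ccc(-c2cc(C(O)(C(F)(F)F)C(F)(F)F)cnc2N2CCN(S(=O)(=O)c3ccc(N)nc3)CC2)cc1` gives 32 mL.min-1.g-1, which places it level with compound 2: a 1.2-fold lower number from compound 2 to compound 3 (0.07 log units; within the scatter). Both sit apart from the methoxy compound, with an at least 2.7-fold higher number from compound 1 to compound 2 (0.43 log units; beyond the scatter) and an at least 2.2-fold higher number from compound 1 to compound 3 (0.35 log units; beyond the scatter).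

Compound 4 `Nc1ccc(S(=O)(=O)N2CCN(c3ncc(C(O)(C(F)(F)F)C(F)(F)F)cc3-c3cncc(F)c3)CC2)cn1` has not yet been measured. It carries 5-fluoropyridin-3-yl in place of 4-(methylsulfonyl)phenyl on an aromatic carbon, ortho to a large group: 5-fluoropyridin-3-yl in place of 4-(methylsulfonyl)phenyl on an aromatic carbon.

The nearest guide is the exchange of cyclopropyl for 4-(methylsulfonyl)phenyl at this same place, which stayed within the scatter: a 1.2-fold lower number from compound 2 to compound 3 (0.07 log units; within the scatter). The steps away from methoxy are larger, but compound 4, like compound 3, has no methoxy group, so they bear on it less. One aromatic ring replacing another is therefore expected to cause no step beyond the scatter in this assay. The estimated change is a 1.1-fold lower number from compound 3 to compound 4 (0.03 log units; within the scatter). The expected value for compound 4 is 30 mL.min-1.g-1, within an estimated range of 15 mL.min-1.g-1 to 60 mL.min-1.g-1.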

Compound 4, intrinsic clearance in microsomes: 24 mL.min-1.g-1
Beside the measured number, compound 4's estimate is 1.3-fold (0.10 log units) above it; low and high end bracket the measured number.
By their numbers in this assay, from the lowest: compounds 4, 3 and 2 (each within the scatter of the next). At a limit, below all of these: compound 1.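

In this assay, a third aromatic or ring group at this place, 5-fluoropyridin-3-yl, stays level with the two groups already tried there, with a 1.3-fold lower number from compound 3 to compound 4 (0.12 log units; within the scatter) and a 1.6-fold lower number from compound 2 to compound 4 (0.20 log units; within the scatter). The change from compound 3 is a real change in the group, since a ring of carbon only gives way to a ring with a hetero atom, and the group that enters has fewer heavy atoms and no double bonds outside the ring, yet at this place, ortho to a large group, the number stays within the scatter. Unlike compounds 2 and 3, compound 4 no longer sits clearly apart from the methoxy compound, with an at least 1.7-fold higher number from compound 1 to compound 4 (0.23 log units; that floor lies within the scatter), and that comparison rests on a limit and not on a number: the limit of < 14 mL.min-1.g-1 in this assay, at which 1 of the 4 values shown sits.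

The groups shown here are methoxy, cyclopropyl and two aromatic rings, so it stays open whether an amine, a carboxylic acid or a longer alkyl chain at this place would stay level with compounds 2, 3 and 4 or move towards compound 1. From the compounds shown here alone, it is also open whether moving the fluorine or the ring nitrogen of 5-fluoropyridin-3-yl to another ring position would change the number.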